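From One Fluorine to Two on the Amide Phenyl

A few compounds are considered here, and "the series" means these few. Any claim that something is new, unique, unknown or untested is made for them only; others in the source may bear on it.

Of the compounds shown here, three sharing one core have been measured so far. In a functional assay on HL-60 cells (Homo sapiens) for cytotoxicity, read by MTT assay, with a stated time of 24 h (a lower number here means a stronger inhibitor, a higher number a weaker inhibitor), compound 1 `CCCCCCCCCCn1cc(Cn2nc(N)c3c(C(F)(F)F)cc(-c4ccccc4)nc32)nn1` gives 29.9 ug/mL as its reading. Compound 2 `Nc1nn(Cc2cn(CC(=O)Nc3ccccc3)nn2)c2nc(-c3ccccc3)cc(C(F)(F)F)c12` gives 96.3 ug/mL and compound 3 `Nc1nn(Cc2cn(CC(=O)Nc3ccc(F)cc3)nn2)c2nc(-c3ccccc3)cc(C(F)(F)F)c12` gives 44.8 ug/mL in the same test. Compound 3 therefore stands second highest of the three numbers, although it cannot be separated from its nearest neighbour: the measured difference is a 1.5-fold higher number from compound 1 to compound 3 (0.18 log units; within the scatter) and comes from (4-fluorophenyl)carbamoyl in place of nonyl.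

Compound 4 `Nc1nn(Cc2cn(CC(=O)Nc3c(F)cccc3F)nn2)c2nc(-c3ccccc3)cc(C(F)(F)F)c12` carries 2,6-difluorophenyl in place of 4-fluorophenyl on an amide-type nitrogen, and the count of that swap reads 2,6-difluorophenyl in place of 4-fluorophenyl on an amide-type nitrogen in full. The closest measured precedent is a 2.1-fold lower number from compound 2 to compound 3 (0.33 log units; beyond the scatter) and comes from fluoro in place of hydrogen on an aromatic carbon. Among the compounds with values here, that modest step is the only fluorine comparison available. Within the data shown here, no measured compound carries the 2,6-difluorophenyl group, so the data give no firm direction in this assay for this swap. The estimate is therefore a 1.1-fold lower number from compound 3 to compound 4 (0.03 log units; within the scatter) as the expected step, with no change expected beyond the scatter. For compound 4 the expected value is 42 ug/mL with an estimated range from 20 ug/mL to 85 ug/mL around it.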

Compound 4, half-maximal inhibitory concentration: 32.8 ug/mL
Compound 4: the middle estimate sits 1.3-fold (0.11 log units) above what was measured, within the range that was stated.
By their numbers in this assay, from the lowest: compounds 1, 4 and 3 (each within the scatter of the next); then compound 2.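

In this assay the change from 4-fluorophenyl to 2,6-difluorophenyl on the amide-type nitrogen gives a 1.4-fold lower number from compound 3 to compound 4 (0.14 log units; within the scatter) and so cannot be read as a real difference: at this position, the second fluorine and the altered fluorine placement leave no measurable mark. The comparison with the plain phenyl group tells a different story, with a 2.9-fold lower number from compound 2 to compound 4 (0.47 log units; beyond the scatter) now standing alongside the earlier 2.1-fold lower number from compound 2 to compound 3 (0.33 log units; beyond the scatter) as a second modest step, so both fluorinated phenyl groups measured here part from plain phenyl by more than the scatter. The new compound also gives a 1.1-fold higher number from compound 1 to compound 4 (0.04 log units; within the scatter) in this assay when its (2,6-difluorophenyl)carbamoyl group is set against the nonyl chain, so that chain and this much larger change in the group on the same carbon cannot be separated by their numbers.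

Nothing available explains why these steps have the size they do. From the compounds shown here alone, it remains open whether a chlorophenyl group, a benzyl group or a phenyl ring carrying a carboxylic acid on the amide-type nitrogen would follow the two fluorinated groups or fall nearer to plain phenyl.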